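Swapping a phenyl for an amide at the limit of the assay

A few compounds are considered here, and "the series" means these few. Any claim that something is new, unique, unknown or untested is made for them only; others in the source may bear on it.

compound 1 `c1ccc(-c2ccc(Cn3cncc3CNc3cccc(-c4ccccc4)c3)cc2)cc1`: 10000 nM
compound 2 `O=C(c1ccc(NCc2cncn2Cc2ccc(-c3ccccc3)cc2)cc1-c1ccccc1)N1CCCCC1`: > 1000 nM
compound 3 `c1ccc(-c2ccc(Cn3cncc3CNc3ccc(-c4ccccc4)c(-c4ccccc4)c3)cc2)cc1`: > 10000 nM
compound 4 `CNC(=O)c1ccc(NCc2cncn2Cc2ccc(-c3ccccc3)cc2)cc1-c1ccccc1`: not yet measured

These values come from a toxicity assay on NIH3T3 cells (Mus musculus) for cytotoxicity, read by resazurin assay; on this read-out lower numbers stand for an effect already at smaller amounts and higher numbers for an effect only at larger amounts of compound. Only compound 1 has a true number there, 10000 nM. Compound 2 has only a limit, > 1000 nM. Going by these compounds, compound 3 also has only a limit, > 10000 nM, so its exact position is unknown.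

The next change is methylcarbamoyl in place of phenyl on an aromatic carbon. The closest measured exchange is a step that the two limits leave unreadable from compound 2 to compound 3, which also removes or installs a phenyl on an aromatic carbon. Also relevant is a number no lower from compound 1 to compound 3 (the limit leaves the size open). Neither step has a readable size, so no step beyond the usual scatter is expected in this assay, and no direction can be predicted. Among the compounds with values here, the only firm anchor is compound 1 at 10000 nM.

This estimate corresponds to a number no higher from compound 3 to compound 4 (the limit leaves the size open), an expected step that remains uncertain. For compound 4 the expected value is 10000 nM, with an estimated range from 3000 nM to 30000 nM.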

Compound 4, half-maximal effective concentration: > 1000 nM
Compound 4: no number, only a limit; the forecaster's own chance of this, stated with the estimate: 60%; the middle value lies beyond the limit too.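

Compound 4 gives only a limit, > 1000 nM, so its steps from compound 1, compound 2 and compound 3 cannot be read. The compounds shown leave open whether swapping these groups on the shared core changes cytotoxicity at all, and in which direction.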